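Cytotoxicity on RD Cells Across an Oxadiazole Replacement

This account rests on a few compounds, and the source may have more. Where it says the series, first, only, none or still open, it means among the compounds named here.

Of the compounds shown here, three have been measured in an ADME assay on RD cells (Homo sapiens) for cytotoxicity, read by MTT assay, with a stated time of 24 h; a higher number here means that more compound is tolerated, a lower number that less compound is tolerated. Compound 1 `CC(CCOc1ccc(-c2noc(C(F)(F)F)n2)cc1)CCN1CCN(c2ccnc(N)c2)C1=O` gives 48100 nM, which places it at the top of the two numbers shown. Compound 2 `Cc1nc(-c2cc(C)c(OCCC(C)CCN3CCN(c4ccnc(N)c4)C3=O)c(C)c2)no1` gives 28800 nM, a value within the scatter of compound 1, so the two cannot be told apart. Going by the values given here, compound 3 `CCO/N=C/c1ccc(OCCC(C)CCN2CCN(c3cccc(N)c3)C2=O)cc1` yields only a limit of this assay, > 100000 nM. the limit of > 100000 nM in this assay, at which 1 of the 3 values shown sits, marks the single value that sits at that limit.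

Compound 4 `CCONCc1ccc(OCCC(C)CCN2CCN(c3ccnc(N)c3)C2=O)cc1` has not yet been measured. It differs from compound 1 in one place: (ethoxyamino)methyl in place of 5-(trifluoromethyl)-1,2,4-oxadiazol-3-yl on an aromatic carbon. Among the compounds with values here, no measured pair shows this change, so its effect can be judged only from the spread of the numbers, which run from the value of compound 2 up to the limit of compound 3. The step is expected to be modest and upward, with more compound tolerated: a 1.5-fold higher number from compound 1 to compound 4 (0.16 log units; within the scatter) is the estimate. For compound 4 the expected value in this assay is 70000 nM, between 30000 nM and 200000 nM.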

Compound 4, half-maximal cytotoxic concentration: 7370 nM
For compound 4 the middle estimate is 9.5-fold (0.98 log units) above the measured one; measured number outside the range, below it.
By their numbers in this assay, from the lowest: compound 4; then compounds 2 and 1 (each within the scatter of the next). At a limit, above all of these: compound 3.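

This position on an aromatic carbon, para to a large group, turns out to matter in this assay: (ethoxyamino)methyl in place of 5-(trifluoromethyl)-1,2,4-oxadiazol-3-yl gives a 6.5-fold lower number from compound 1 to compound 4 (0.81 log units; beyond the scatter). Going by these compounds alone, this is the first pair that differs in one place, and it shows that less compound is tolerated when the five-membered aromatic ring gives way to a group with no ring. Nothing measured here accounts for the size of this step.

The compounds shown leave open whether a simple amine, a carboxylic acid or a longer ether chain at this position would stay close to compound 1 or move toward compound 4. They also leave open whether the same replacement would give a step of similar size in other members of the series.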